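A few compounds are considered here, and "the series" means these few. Any claim that something is new, unique, unknown or untested is made for them only; others in the source may bear on it.

Measured compounds:
compound 1 `Cc1cc(C)nc(Oc2ccc(NC(=O)Nc3ccccc3)cc2)n1` — "not determined" (no result reported)
compound 2 `Cc1cccc(NC(=O)Nc2ccc(Oc3nc(C)cc(C)n3)cc2)c1` — "not determined" (no result reported)
compound 3 `Cc1cc(C)nc(Oc2ccc(NC(=O)Nc3ccc(OC(F)(F)F)cc3)cc2)n1` — > 50000 nM

Compounds 1 and 2 carry no result in a functional assay on MGC-803 cells (Homo sapiens) for cytotoxicity, read by MTT assay, with a stated time of 3 days; a lower number here means a stronger inhibitor, a higher number a weaker inhibitor. In this assay compound 3 reaches > 50000 nM, which is a limit of the assay and not a number. Among the measured compounds shown here, compound 3 therefore stands as the single entry with any reading, and it sits at the limit of > 50000 nM in this assay, at which 1 of the 3 values shown sits. For the measured compounds named here, no step between two measured compounds is available, so no size for a change can be read from the series.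

Compound 4 `Cc1cc(C)nc(Oc2ccc(NC(=O)Nc3ccc(F)cc3)cc2)n1` differs from compound 3 by fluoro in place of trifluoromethoxy on an aromatic carbon. Going by the values given here, with no measured step to lean on, no change beyond the scatter is assumed in this assay. Compound 4 is expected at 60000 nM, with a range from 15000 nM to 200000 nM. The expected step is a step that the limit leaves unreadable from compound 3 to compound 4, and a limit rather than a number remains the likely outcome because compound 3 stands at the limit of > 50000 nM in this assay, at which 1 of the 3 values shown sits.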

Compound 4, half-maximal inhibitory concentration: > 50000 nM
Compound 4: no number, only a limit (the forecaster's own chance of this, stated with the estimate: 75%); the middle value does not contradict the limit.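

In this assay compound 3 and compound 4 each give a limit, not a number, so the step between them cannot be read. The compounds shown leave open whether exchanging trifluoromethoxy for fluoro changes cytotoxicity at all.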